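A Halogen Swap on the Sulfonyl Aryl Ring

The source may report more compounds than this note shows. Statements on the series, on what has been measured and on what is new or still open speak of the compounds shown alone.

Of the compounds shown here, three of a shared core have been measured in a functional assay on CHO.K1 cells for antagonist activity at prostaglandin D2 receptor 2 (Homo sapiens), read by GTPgammaS binding, with a stated time of 1 h; on this read-out lower numbers stand for stronger inhibition and higher numbers for weaker inhibition. Compound 1 `COC(=O)c1ccc(Cc2c3c(n(CC(=O)O)c2C)CCNC3=O)c(S(=O)(=O)c2ccccc2)c1` gives 11 nM in this assay. Compound 2 `Cc1c(Cc2cc(F)ccc2S(=O)(=O)c2ccccc2)c2c(n1CC(=O)O)CCNC2=O` gives 3.7 nM in this assay. Compound 3 `Cc1c(Cc2ccccc2S(=O)(=O)c2cccc(Cl)c2)c2c(n1CC(=O)O)CCNC2=O` gives 4 nM in this assay, the second highest of the three numbers; its nearest neighbour is compound 2, whose number lies within the usual scatter of it, and its furthest is compound 1, whose number sits beyond the scatter.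

Compound 4 `Cc1c(Cc2ccccc2S(=O)(=O)c2ccc(F)cc2)c2c(n1CC(=O)O)CCNC2=O` differs from compound 3 in one place: 4-fluorophenyl in place of 3-chlorophenyl on a sulfonyl sulfur. Among the measured compounds shown here, no pair of measured compounds differs only on the sulfonyl aryl ring, so no measured step isolates this kind of change; compound 1 carries an unsubstituted phenyl on its sulfonyl sulfur, but it also differs from compound 3 elsewhere, and its value cannot be read as the effect of the sulfonyl ring alone.

Given that the two halogenated compounds 2 and 3 sit close together, compound 4 is expected to show no step beyond the scatter, a 1.3-fold higher number from compound 3 to compound 4 (0.10 log units; within the scatter). The estimate for compound 4 in this assay is 5 nM, with an expected range from 2 nM to 14 nM.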

Compound 4, half-maximal inhibitory concentration: 3.3 nM
Estimate against measurement, compound 4: 1.5-fold (0.18 log units) above, within the range that was stated.
By their numbers in this assay, from the lowest: compounds 4, 2 and 3 (each within the scatter of the next); then compound 1.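

In this assay, among the compounds shown here, the exchange of 3-chlorophenyl for 4-fluorophenyl on a sulfonyl sulfur gives a 1.2-fold lower number from compound 3 to compound 4 (0.08 log units; within the scatter), and this is the first measured step that isolates the sulfonyl aryl ring. It shows that, with the rest of the molecule held fixed, these two halogenated rings cannot be told apart on this read-out, even though the step changes both the halogen and where it stands on the ring. No accompanying measurement offers an explanation for this result.

Going by these compounds, with both features changing at once, this single step cannot show whether either the halogen or its place on the ring matters by itself, and how the unsubstituted phenyl compares on an otherwise identical molecule also stays open. Nor do the compounds shown tell whether this tolerance extends beyond halogens, for instance to a ring bearing an amine, a carboxylic acid or a methoxy group, or to a pyridine ring in place of the phenyl.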